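Removing a Ring Hydroxy Group: Expected Cytotoxicity of Compound 4

The compounds below may be only part of what the source reports. "The series", "measured", "known", "first", "only" and "open" are said of these compounds alone.

compound 1 `COc1cc(/C=C/C(=O)OC[C@H](Cc2ccc(O)c(OC)c2)[C@H](CO)Cc2ccc(O)c(OC)c2)ccc1O` — 35.2 ug/mL
compound 2 `C=C[C@@]1(C)COC(=O)[C@]12OC([C@H](C)CC)=CC2=O` — > 100 ug/mL
compound 3 `C=C[C@@]1(C)COC(=O)C1(O)C(=O)/C=C(\O)c1ccccc1` — > 100 ug/mL

In a functional assay on K562 cells (Homo sapiens) for cytotoxicity, read by MTT assay, with a stated time of 48 h (a lower number here means a stronger inhibitor, a higher number a weaker inhibitor), compound 1 gives 35.2 ug/mL. Compound 2 reaches only a limit of the assay, > 100 ug/mL. Compound 3 likewise stands at a limit, > 100 ug/mL, so no number is known for it, and the limit of > 100 ug/mL in this assay, at which 2 of the 3 values shown sit, is the only point of reference for it. Going by the values given here, no pair of measured compounds differs in a single place, so no measured step is available.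

Compound 4 `C=C[C@@]1(C)COC(=O)C1C(=O)/C=C(\O)c1ccccc1` differs from compound 3 by hydrogen in place of hydroxy on a saturated ring carbon. Since compound 3 sits at a limit, the step can only be guessed; it is expected to be a number no higher from compound 3 to compound 4 (the limit leaves the size open), none beyond the scatter. Compound 4 is therefore estimated at 100 ug/mL, between 40 ug/mL and 250 ug/mL, most likely again a limit.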

Compound 4, half-maximal inhibitory concentration: 47.8 ug/mL
The estimate for compound 4 lay 2.1-fold (0.32 log units) above the measured number, within the range that was stated.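

In this assay, going by these compounds alone, the hydroxy group on the saturated ring carbon is the first single place where a change can be read: hydrogen in its stead gives an at least 2.0-fold lower number from compound 3 to compound 4 (0.32 log units; beyond the scatter), beyond the scatter. Compound 4 has a measured number, so loss of this hydroxy group does not abolish the read-out. Compound 3 remains a limit, > 100 ug/mL, which leaves the full size of the step unknown: the limit of > 100 ug/mL in this assay, at which 2 of the 4 values shown sit.

Going by these compounds, whether an amine or a fluorine atom on this ring carbon would give a lower number than hydrogen stays open. So does whether this step would hold on another core.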